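Moving the Amine from 4-Aminophenyl to 3-Aminophenyl

This account rests on a few compounds, and the source may have more. Where it says the series, first, only, none or still open, it means among the compounds named here.

In a functional assay on K562 cells (Homo sapiens) for cytotoxicity, with a stated time of 48 h (a lower number here means a stronger inhibitor, a higher number a weaker inhibitor), compound 1 (`COc1ccc(/C=C\c2ccc3c(c2)C(C)(C)CCC3(C)C)cc1N`) gives 42000 nM and compound 2 (`CC1(C)CCC(C)(C)c2cc(/C=C\c3ccc(N)cc3)ccc21`) gives 50000 nM, two values within the scatter of each other. Compound 3 (`CC1(C)CCC(C)(C)c2cc(/C=C\c3cccc(N)c3)ccc21`) is still unmeasured and differs from compound 2 by one change (3-aminophenyl in place of 4-aminophenyl on a double-bonded chain carbon bound to a double-bonded chain carbon) with 3-aminophenyl in place of 4-aminophenyl on a double-bonded chain carbon bound to a double-bonded chain carbon. Among the compounds with values here, no measured pair shows such a change, so with compound 2 at 50000 nM as the reference, no step beyond the scatter is expected in this assay for it. An estimated step (a 1.4-fold lower number from compound 2 to compound 3 (0.15 log units; within the scatter)) is expected to stay within the scatter. Compound 3 is estimated at 35000 nM (expected range 10000 nM to 100000 nM).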

Compound 3, half-maximal inhibitory concentration: 13000 nM
Estimate against measurement, compound 3: 2.7-fold (0.43 log units) above, within the range that was stated.
By their numbers in this assay, from the lowest: compound 3; then compounds 1 and 2 (each within the scatter of the next).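

In this assay, the place of the amine on the ring now proves to matter: 3-aminophenyl in place of 4-aminophenyl, with the same atoms joined differently, gives a 3.8-fold lower number from compound 2 to compound 3 (0.59 log units; beyond the scatter), a separation that compounds 1 and 2 did not show. Hydrogen in place of methoxy on an aromatic carbon gives a 3.2-fold lower number from compound 1 to compound 3 (0.51 log units; beyond the scatter), so the methoxy-bearing compound 1 also stands apart from compound 3. No measurement shown explains either step. The compounds shown leave open how a hydroxyl, a carboxylic acid or an acetamide would compare with the amine on this ring.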